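Cyclopentyl on the sulfur of compound 3

A few compounds are considered here, and "the series" means these few. Any claim that something is new, unique, unknown or untested is made for them only; others in the source may bear on it.

Compound 1 `CCC(C)Sc1nc(C(C)c2c(F)cccc2Cl)c(C)c(=O)[nH]1`, compound 2 `CCC(c1nc(SC(C)C)[nH]c(=O)c1C)c1c(F)cccc1Cl` and compound 3 `CCC(c1nc(SC(C)C)[nH]c(=O)c1C)c1c(F)cccc1F` all read as limits in an ADME assay on MT4 cells (Homo sapiens) for activation, read by MTT assay; on this read-out lower numbers stand for higher toxicity in this test and higher numbers for lower toxicity in this test. Compound 1 gives the limit > 1500 nM. Compound 2 gives the limit > 3000 nM. Compound 3 gives the limit > 30000 nM.

Compound 4 `CCC(c1nc(SC2CCCC2)[nH]c(=O)c1C)c1c(F)cccc1F` differs from compound 3 by one change: cyclopentyl in place of isopropyl on a sulfur. Within the data shown here, the only measured step is a step that the two limits leave unreadable from compound 2 to compound 3, with fluoro in place of chloro on an aromatic carbon. It has no readable size and does not involve the group on the sulfur, so it gives no guide to size or direction.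

In this assay the expected step is a number no higher from compound 3 to compound 4 (the limit leaves the size open), with none expected beyond the scatter. The estimate for compound 4 is 30000 nM, with an expected range of 8000 nM to 100000 nM.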

Compound 4, half-maximal cytotoxic concentration: 30000 nM
Compound 4: the middle estimate sits on the measured number at the digits printed; low and high end bracket the measured number.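

In this assay, among these compounds, compound 4 gives 30000 nM, the only value shown that is a number and not a limit. Compound 3 gives > 30000 nM, which is a limit. Cyclopentyl in place of isopropyl on the sulfur gives a number no higher from compound 3 to compound 4 (the limit leaves the size open), and neither this step nor the earlier one can be read in size.

Open, as far as these compounds go, is how a longer chain or an amine on the sulfur would read. Also open, from the compounds shown here alone, is how cyclopentyl on the sulfur reads with chloro in place of fluoro on the aromatic carbon.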